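Swapping an Aryl Ketone for a Cyclopropyl Ketone

The compounds below may be only part of what the source reports. "The series", "measured", "known", "first", "only" and "open" are said of these compounds alone.

Two measured compounds share one core. In a functional assay on PC-3 cells (Homo sapiens) for cytotoxicity, read by MTT assay, with a stated time of 48 h (on this read-out higher numbers stand for weaker inhibition and lower numbers for stronger inhibition), compound 2 `COc1cc(-c2nnc3n2NC(c2ccco2)C(C(=O)c2ccc(F)c(F)c2)S3)cc(OC)c1OC` gives 36000 nM, the lower of the two numbers; compound 1 `COc1cc(-c2nnc3n2NC(c2cccs2)C(C(=O)c2ccccc2)S3)cc(OC)c1OC` gives 86300 nM, a gap beyond the usual scatter. Compound 3 `COc1cc(-c2nnc3n2NC(c2ccco2)C(C(=O)C2CC2)S3)cc(OC)c1OC` differs from compound 2 in one place: cyclopropyl in place of 3,4-difluorophenyl on a carbonyl carbon. Among the compounds with values here, no measured pair shows this change, so its direction is not known from these data; a modest step is expected, likely toward weaker inhibition. Compound 3 is therefore estimated at 55000 nM in this assay, within a range from 15000 nM to 180000 nM, a step of a 1.5-fold higher number from compound 2 to compound 3 (0.18 log units; within the scatter).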

Compound 3, half-maximal inhibitory concentration: 95200 nM
Compound 3: the middle estimate sits 1.7-fold (0.24 log units) below what was measured; low and high end bracket the measured number.
By their numbers in this assay, from the lowest: compound 2; then compounds 1 and 3 (each within the scatter of the next).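

Cyclopropyl in place of 3,4-difluorophenyl on a carbonyl carbon gives a 2.6-fold higher number from compound 2 to compound 3 (0.42 log units; beyond the scatter) in this assay and so weakens inhibition. This single-place pair shows that the group on this carbonyl carbon can alter the read-out, and that here the aromatic ring gives the stronger inhibition of the two. No measurement shown bears on why the step occurs.

From the compounds shown here alone, whether ring size or aromatic character matters remains open. A cyclohexyl ring or a methyl group on this carbonyl carbon could help separate the two.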